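Chalcone series: dihydroxyphenyl in place of methylphenyl

The source may report more compounds than this note shows. Statements on the series, on what has been measured and on what is new or still open speak of the compounds shown alone.

Among the measured compounds shown here, compound 1 `COc1cc(OC)c(OC)cc1/C=C/C(=O)c1ccc(C)cc1` is the only member of the set with a numerical result: in a functional assay on MCF7 cells (Homo sapiens) for inhibition, read by MTT assay, with a stated time of 72 h (on this read-out higher numbers stand for weaker inhibition and lower numbers for stronger inhibition), compound 1 gives 33000 nM. Compound 2 `COc1cc(OC)c(OC)cc1/C=C/C(=O)c1ccc([N+](=O)[O-])cc1` reaches only a limit of the assay in this assay, at > 150000 nM. Compound 3 `COc1cc(OC)c(OC)cc1/C=C/C(=O)c1ccc(-c2c[nH]cn2)cc1` likewise stops at a limit in this assay, at > 150000 nM. Both an at least 4.5-fold higher number from compound 1 to compound 2 (0.65 log units; beyond the scatter) and an at least 4.5-fold higher number from compound 1 to compound 3 (0.65 log units; beyond the scatter) therefore end at the limit of > 150000 nM in this assay, at which 2 of the 3 values shown sit, and a step that the two limits leave unreadable from compound 2 to compound 3.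

Compound 4 `COc1cc(OC)c(OC)cc1/C=C/C(=O)c1cc(O)ccc1O` is the unmeasured member; the change from compound 1 is 2,5-dihydroxyphenyl in place of 4-methylphenyl on a carbonyl carbon. The two measured steps bear on it only loosely: each replaced the methyl with a different group on the ring attached to the carbonyl carbon, and each weakened inhibition to the limit. The change to compound 4 again alters that ring, now with a 2,5-dihydroxyphenyl, so a step toward higher numbers is expected, a 2.4-fold higher number from compound 1 to compound 4 (0.38 log units; beyond the scatter), with a real chance that only a limit is returned. Compound 4 is therefore estimated at 80000 nM, in the range 20000 nM to 200000 nM.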

Compound 4, half-maximal inhibitory concentration: > 150000 nM
Compound 4: a limit, no number (the forecaster's own chance of this, stated with the estimate: 35%); middle value at least 1.8-fold (0.27 log units) from the limit.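

an at least 4.5-fold higher number from compound 1 to compound 4 (0.65 log units; beyond the scatter) in this assay follows from 2,5-dihydroxyphenyl in place of 4-methylphenyl on the carbonyl carbon. Compound 4 gives > 150000 nM, which is a limit of the assay and not a number. A replacement that brings in hydroxyl groups and removes the methyl therefore ends like the nitro and 1H-imidazol-4-yl replacements, and compound 1 is the only compound shown that goes against this pattern: the limit of > 150000 nM in this assay, at which 3 of the 4 values shown sit.

Steps among compounds 2, 3 and 4 cannot be read, so no order among these replacements can be given. Open, from the compounds shown here alone, is whether an ethyl or methoxy group in place of the methyl, or an amine on that ring, would give a number in this assay, and how such a number would stand against compound 1 at 33000 nM.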